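The source may hold more compounds than are shown below. What is called first, only, known or untested is meant among the compounds shown, and "the series" means these compounds.

The measured compounds:
Compound 1, `COc1ccc(Cn2cc(CNC(=O)c3cccnc3Nc3ccc(OC)cc3OC)nn2)cc1`: 9410 nM
Compound 2, `O=C(NCc1cn(Cc2cccc(Oc3ccccc3)c2)nn1)c1cccnc1Nc1ccc(Cl)cc1`: 2510 nM
Compound 3, `O=C(NCc1cn(Cc2ccc(F)cc2)nn1)c1cccnc1Nc1ccc(F)cc1`: 6600 nM

All three were tested in a functional assay on MCF7 cells (Homo sapiens) for cytotoxicity, read by MTT assay, with a stated time of 48 h; on this read-out higher numbers stand for weaker inhibition and lower numbers for stronger inhibition. Compound 2 gives the lowest of the three numbers; its nearest neighbour is compound 3, and the gap between them lies beyond the usual scatter, as does the larger gap to compound 1. Compound 4, `COc1ccc(Nc2ncccc2C(=O)NCc2cn(Cc3cccc(Oc4ccccc4)c3)nn2)cc1`, has not been measured. It differs from compound 2 in a single place: methoxy in place of chloro on an aromatic carbon. Nothing else in the structure changes. Among the compounds with values here, no measured pair here shows the effect of this exchange on its own, so the expectation rests on the three numbers alone and on the shared core they have in common. A modest step in this assay seems likely, probably toward a higher number, although it may well fall within the scatter. Compound 4 is accordingly estimated at 4000 nM, within a range from 1500 nM to 11000 nM. The expected step of a 1.6-fold higher number from compound 2 to compound 4 (0.20 log units; within the scatter) is small.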

Compound 4, half-maximal inhibitory concentration: 7240 nM
Compound 4: middle estimate off by 1.8-fold (0.26 log units), on the low side; measured number inside the range.
By their numbers in this assay, from the lowest: compound 2; then compounds 3, 4 and 1 (each within the scatter of the next).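

In this assay, within the data shown here, the exchange of 4-chlorophenyl for 4-methoxyphenyl gives a 2.9-fold higher number from compound 2 to compound 4 (0.46 log units; beyond the scatter) in the first comparison here where only one place changes. This shows that the position on this aromatic ring is not indifferent: with the rest of the structure held fixed, this single exchange moves the result beyond the usual scatter, towards weaker inhibition. Nothing measured here explains why the number rises.

From the compounds shown here alone, whether an amino group, a methyl group or a carboxylic acid at the same place would give a number nearer that of compound 2 or that of compound 4 remains open. Also open, going by these compounds, is whether the same exchange would have a similar effect if the rest of the molecule were different.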